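The source may hold more compounds than are shown below. What is called first, only, known or untested is meant among the compounds shown, and "the series" means these compounds.

Values in a functional assay on SNB-78 cells (Homo sapiens) for inhibition, read by sulforhodamine B assay, with a stated time of 48 h (on this read-out lower numbers stand for stronger inhibition of growth and higher numbers for weaker inhibition of growth), are as follows
compound 1 `CCCCCCCCCCCC[C@@H](O)[C@H]1CC[C@H]([C@H](O)CCCCCCCCCCNC(=O)c2ccnn2C)O1` gives 100000 nM
compound 2 `CCCCCCCCCCCC[C@@H](O)[C@H]1CC[C@H]([C@H](O)CCCCCCCCCCN(C)C(=O)c2ccnn2C)O1` gives 12000 nM
compound 3 `CCCCCCCCCCCC[C@@H](O)[C@H]1CC[C@H]([C@H](O)CCCCCCCCCCNCc2ccnn2C)O1` gives 2090 nM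

Compound 3 has the lowest number of these three. Compound 4 `CCCCCCCCCCCC[C@@H](O)[C@H]1CC[C@H]([C@H](O)CCCCCCCCCCC(=O)Nc2ccnn2C)O1` differs from it at the end of the chain ((1-methyl-1H-pyrazol-5-yl)carbamoyl in place of ((1-methyl-1H-pyrazol-5-yl)methyl)amino on a saturated chain carbon, ten or more bonds along the chain from an oxygen on a saturated carbon and a saturated ring carbon). Its new group, (1-methyl-1H-pyrazol-5-yl)carbamoyl, brings back a carbonyl and, like compound 1, keeps a hydrogen on the amide nitrogen, although the amide runs the other way round. Two steps to the amine bear on this, one large (a 48-fold lower number from compound 1 to compound 3 (1.68 log units; beyond the scatter)) and one modest (a 5.7-fold lower number from compound 2 to compound 3 (0.76 log units; beyond the scatter)). Going by the values given here, no tested compound carries this reversed amide, so the comparison is loose. A move to a higher number is expected, estimated as (a 9.6-fold higher number from compound 3 to compound 4 (0.98 log units; beyond the scatter)) in this assay. The expected value for compound 4 is 20000 nM, with an estimated range from 4000 nM to 100000 nM.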

Compound 4, concentration for 50% growth inhibition: 100000 nM
Compound 4: the middle estimate sits 5.0-fold (0.70 log units) below what was measured; low and high end bracket the measured number.
By their numbers in this assay, from the lowest: compound 3; then compound 2; then compounds 1 and 4 (each within the scatter of the next).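

In this assay, the reversed amide gives up everything gained with the amine (a 48-fold higher number from compound 3 to compound 4 (1.68 log units; beyond the scatter)) and also falls short of the methylated amide (an 8.3-fold higher number from compound 2 to compound 4 (0.92 log units; beyond the scatter)). Which way round the amide runs does not matter here, provided the amide hydrogen stays (no change at the digits printed from compound 1 to compound 4 (within the scatter)). No measurement shown explains these steps. As far as these compounds go, it remains open whether a methyl on the nitrogen of the reversed amide would bring a gain like that seen for compound 2. A carboxylic acid or a longer chain at this position is also untested in the compounds shown.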